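From 3-carboxypropyl to 2-carboxyphenyl on a shared core

This account rests on a few compounds, and the source may have more. Where it says the series, first, only, none or still open, it means among the compounds named here.

- Compound 1 `O=C(O)CCC(=O)OCCOc1no[n+]([O-])c1S(=O)(=O)c1ccccc1` measured 3800 nM
- Compound 2 `O=C(O)CCCC(=O)OCCOc1no[n+]([O-])c1S(=O)(=O)c1ccccc1` measured 5100 nM

In a functional assay on PC-3 cells (Homo sapiens) for antiproliferative activity, read by MTT assay, with a stated time of 72 h (on this read-out lower numbers stand for stronger inhibition and higher numbers for weaker inhibition), compound 2 stands at 5100 nM and so lies within the scatter of compound 1. Compound 3 `O=C(O)c1ccccc1C(=O)OCCOc1no[n+]([O-])c1S(=O)(=O)c1ccccc1` carries 2-carboxyphenyl in place of 3-carboxypropyl on a carbonyl carbon. Within the data shown here, the only measured step, a 1.3-fold higher number from compound 1 to compound 2 (0.13 log units; within the scatter), brings no ring into that place, so it is a weak guide. The expected step is a 1.1-fold lower number from compound 2 to compound 3 (0.05 log units; within the scatter) in this assay and nothing beyond the scatter is expected, in either direction. The estimate for compound 3 is 4500 nM with an expected range from 1500 nM to 13000 nM in this measurement.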

Compound 3, half-maximal inhibitory concentration: 9900 nM
Compound 3: the middle estimate sits 2.2-fold (0.34 log units) below what was measured; measured number inside the range.
By their numbers in this assay, from the lowest: compounds 1, 2 and 3 (each within the scatter of the next, the first and the last beyond it).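

Placing a ring on this carbonyl carbon gives the first step in the series that clears the scatter, with 2-carboxyphenyl in place of 2-carboxyethyl (a 2.6-fold higher number from compound 1 to compound 3 (0.42 log units; beyond the scatter)). Set against 3-carboxypropyl, the same ring stays within the scatter (a 1.9-fold higher number from compound 2 to compound 3 (0.29 log units; within the scatter)), so the loss is modest and rests on a single comparison. Nothing available explains this step.

On these data alone, what an amine or a longer chain ending in a carboxylic acid would give at this place remains open. So does whether a plain phenyl ring would behave like 2-carboxyphenyl.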